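Sulfonamide cap in place of the free amine on compound 3

A few compounds are considered here, and "the series" means these few. Any claim that something is new, unique, unknown or untested is made for them only; others in the source may bear on it.

Within the data shown here, compound 3 `CC(C)(C)c1ccc(C(=O)N2CCC3(CC2)C(=O)N(CC(=O)NCCCN)CN3c2ccccc2)cc1` gives the lowest number so far in an assay on HEK293 cells for displacement of a labelled ligand from NPC1-like intracellular cholesterol transporter 1 (Homo sapiens) (a higher number here means a weaker inhibitor, a lower number a stronger inhibitor), with 4200 nM. Compound 1 `CC(C)(C)c1ccc(C(=O)N2CCC3(CC2)C(=O)N(CC(=O)N2CCN(S(C)(=O)=O)CC2)CN3c2ccccc2)cc1` gives 19000 nM and compound 2 `CC(C)(C)OC(=O)NCCCCCNC(=O)CN1CN(c2ccccc2)C2(CCN(C(=O)c3ccc(C(C)(C)C)cc3)CC2)C1=O` gives 13700 nM in this assay. Compound 4 `CC(C)(C)c1ccc(C(=O)N2CCC3(CC2)C(=O)N(CC(=O)NCNS(C)(=O)=O)CN3c2ccccc2)cc1` differs from compound 3 by methanesulfonamido in place of 2-aminoethyl on a saturated chain carbon bound to an amide-type nitrogen. The two steps into compound 3 both bear on this change: a 4.5-fold lower number from compound 1 to compound 3 (0.66 log units; beyond the scatter) and a 3.3-fold lower number from compound 2 to compound 3 (0.51 log units; beyond the scatter), each reached by arriving at a free terminal amine from a capped or sulfonyl-bearing end group. Compound 4 removes that free amine again, so a modest rise in this assay is expected, a 2.9-fold higher number from compound 3 to compound 4 (0.46 log units; beyond the scatter). Compound 4 is therefore estimated at 12000 nM, with a range from 5000 nM to 30000 nM.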

Compound 4, half-maximal inhibitory concentration: 3200 nM
For compound 4 the middle estimate is 3.8-fold (0.57 log units) above the measured one, outside the stated range (below it).
By their numbers in this assay, from the lowest: compounds 4 and 3 (each within the scatter of the next); then compounds 2 and 1 (each within the scatter of the next).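

A free terminal amine is not needed to hold the level reached by compound 3 in this assay: methanesulfonamido in place of 2-aminoethyl gives a 1.3-fold lower number from compound 3 to compound 4 (0.12 log units; within the scatter). The capped end also keeps the distance from the two weaker compounds, with a 4.3-fold lower number from compound 2 to compound 4 (0.63 log units; beyond the scatter) and a 5.9-fold lower number from compound 1 to compound 4 (0.77 log units; beyond the scatter). No evidence on hand gives a reason for this result.

The step from compound 3 to compound 4 alters both chain and end group at once, so the contribution of each remains unresolved. A longer chain ending in methanesulfonamido, or a carboxylic acid at the same end, would help separate them.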